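The source may hold more compounds than are shown below. What is called first, only, known or untested is meant among the compounds shown, and "the series" means these compounds.

Measured so far in a physicochemical assay for solubility, read by spectrophotometry, measured as kinetic solubility, at pH 8, tested at 500 uM; a higher number here means a more soluble compound, a lower number a less soluble compound:
- compound 1 `Cn1ccc2ccc(-c3cc(Nc4cnccc4C(=O)NC4CCNC(=O)C4)cc4nccnc34)cc21`: 242 ug/mL
- compound 2 `CN1CCC(NC(=O)c2ccncc2Nc2cc(-c3ccc4ccn(C)c4c3)c3nccnc3c2)CC1=O`: 48 ug/mL

Not yet measured: compound 3 `CN1CC(NC(=O)c2ccncc2Nc2cc(-c3ccc4ccn(C)c4c3)c3nccnc3c2)CCC1=O`.

Of the two measured compounds, compound 2 has the lower number, at 48 ug/mL. Compound 3 has the same atoms as compound 2, joined differently: 1-methyl-6-oxopiperidin-3-yl in place of 1-methyl-2-oxopiperidin-4-yl on an amide-type nitrogen. In words, 1-methyl-6-oxopiperidin-3-yl takes the place of 1-methyl-2-oxopiperidin-4-yl on an amide-type nitrogen.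

Among the compounds with values here, only one measured step is available: a 5.0-fold lower number from compound 1 to compound 2 (0.70 log units; beyond the scatter), with methyl in place of hydrogen on an amide-type nitrogen in a ring. That is a different change, so it offers only a rough sense of size, and nothing measured here tests the new arrangement. The expected step is small, a 1.1-fold higher number from compound 2 to compound 3 (0.06 log units; within the scatter), and its direction remains uncertain. For compound 3 the estimated value is 55 ug/mL, with an expected range from 22 ug/mL to 130 ug/mL.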

Compound 3, solubility: 253 ug/mL
The estimate for compound 3 lay 4.6-fold (0.66 log units) below the measured number; the whole stated range lies below it.
By their numbers in this assay, from the lowest: compound 2; then compounds 1 and 3 (each within the scatter of the next).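

Compound 2 and compound 3 have the same atoms, joined differently, yet in this assay replacing 1-methyl-2-oxopiperidin-4-yl with 1-methyl-6-oxopiperidin-3-yl on the amide-type nitrogen gives a 5.3-fold higher number from compound 2 to compound 3 (0.72 log units; beyond the scatter), so how this ring is built and attached matters, not just what it contains. The ring methyl alone therefore does not go with a low number: compound 3 also carries a methyl, and the listed step is a 1.0-fold higher number from compound 1 to compound 3 (0.02 log units; within the scatter). Nothing available here explains the gap between compound 2 and compound 3.

Still open, as far as these compounds go, is whether 6-oxopiperidin-3-yl without its methyl would behave like compound 3, which would show what the methyl does in this arrangement. Also open, from the compounds shown here alone, is how a simple piperidine amine, or an open-chain amide, would read at this place.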